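Swapping methyl for methoxy in a cytotoxicity test

This account rests on a few compounds, and the source may have more. Where it says the series, first, only, none or still open, it means among the compounds named here.

Values in an ADME assay on RAW264.7 cells (Mus musculus) for cytotoxicity, read by MTT assay; on this read-out higher numbers stand for weaker inhibition and lower numbers for stronger inhibition:
- Compound 1 `O=C(/C=C/C=C/c1ccccc1)c1ccccc1`: 44300 nM
- Compound 2 `O=C(/C=C/C=C/c1ccccc1)c1cc(Cl)cc(Cl)c1O`: "not determined" (no result reported)
- Compound 3 `Cc1ccc(/C=C/C=C/C(=O)c2ccccc2)cc1`: "not determined" (no result reported)

Only compound 1 has a number, so it is the single fixed point in this small set. Compound 3 has no number to place on that scale, and neither does compound 2. It therefore cannot be ranked against compound 1, and nothing can be said about whether it is more or less toxic to these cells.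

Compound 4 `COc1ccc(/C=C/C=C/C(=O)c2ccccc2)cc1` has not yet been measured. The structural change that leads to it is methoxy in place of methyl on an aromatic carbon, para to a large group.

For the measured compounds named here, no pair of measured compounds shows what a change at this place does, so there is no measured step to borrow. The expectation is therefore modest: no step beyond the usual scatter of this assay, in either direction, with the reading staying in the region of compound 1 at 44300 nM. With one number as a guide, the range has to stay wide. For compound 4 the estimated value is 40000 nM, with an expected range from 15000 nM to 100000 nM.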

Compound 4, half-maximal inhibitory concentration: > 100000 nM
Compound 4: only a limit was reported (the forecaster's own chance of this, stated with the estimate: 15%); middle value at least 2.5-fold (0.39 log units) from the limit.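

In this assay compound 4 gives > 100000 nM, which is a limit of the assay and not a number. Compared with the unsubstituted core, a methoxy group, para to a large group, gives an at least 2.2-fold higher number from compound 1 to compound 4 (0.35 log units; beyond the scatter), so this change at this place moves the reading towards weaker inhibition of the cells, the first measured sign of what a group here can do. The full size of that step stays unknown because the reading is a limit rather than a number: the limit of > 100000 nM in this assay, at which 1 of the 4 values shown sits.

The steps involving compound 2 or compound 3 cannot be read, so it remains unclear whether the shift needs the oxygen of methoxy or whether methyl at the same place would move the reading in the same way. As far as these compounds go, it is also open how other groups at this place would behave, such as an amine, a carboxylic acid or a longer chain like ethoxy, and whether any of them would shift the reading in the opposite direction.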